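Compound 1 to compound 4: methoxy in place of hydrogen

This account rests on a few compounds, and the source may have more. Where it says the series, first, only, none or still open, it means among the compounds named here.

compound 1 `O[C@@H](c1ccccc1)[C@H]1CO[C@H](c2ccccc2)[C@@H](C/C=C/c2ccccc2)C1` gives 6060 nM
compound 2 `COc1ccc(CCC[C@H]2C[C@@H]([C@@H](O)c3ccc(OC)c(OC)c3)CO[C@@H]2c2ccc(OC)c(OC)c2)cc1OC` gives 37700 nM
compound 3 `COc1ccc([C@H]2OC[C@H]([C@@H](O)c3ccc(OC)c(OC)c3)C[C@@H]2C/C=C/c2ccccc2)cc1OC` gives 14800 nM
compound 4 `COc1ccc(/C=C/C[C@H]2C[C@@H]([C@@H](O)c3ccccc3)CO[C@@H]2c2ccccc2)cc1` is not yet measured

In a functional assay on HeLa cells (Homo sapiens) for cytotoxicity, read by WST assay, with a stated time of 48 h (a higher number here means a weaker inhibitor, a lower number a stronger inhibitor), compound 1 stands lowest of the three, with both gaps beyond the scatter. Compound 4 carries methoxy in place of hydrogen on an aromatic carbon on the ring of the 2-phenylethenyl group, giving 2-(4-methoxyphenyl)ethenyl. The nearest measured step is a 2.5-fold lower number from compound 2 to compound 3 (0.41 log units; beyond the scatter) and it is modest. For the measured compounds named here, it mixes methoxy groups with a chain change, so no measured step isolates a single methoxy. Compound 2 and compound 3 both carry methoxy groups and both sit above compound 1. A small rise is therefore expected, possibly within the scatter, and the estimated step is a 1.3-fold higher number from compound 1 to compound 4 (0.12 log units; within the scatter) in this assay as a working figure. For compound 4 the expected value is 8000 nM, with an estimated range from 4000 nM to 16000 nM as the likely span.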

Compound 4, half-maximal inhibitory concentration: 8300 nM
The estimate for compound 4 lay 1.0-fold (0.02 log units) below the measured number, and the stated range covers the measured number.
By their numbers in this assay, from the lowest: compounds 1, 4 and 3 (each within the scatter of the next, the first and the last beyond it); then compound 2.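

In this assay, for the compounds shown here, the change from phenyl to 4-methoxyphenyl isolates one methoxy on the 2-phenylethenyl group, which the earlier compounds did not do, and a 1.4-fold higher number from compound 1 to compound 4 (0.14 log units; within the scatter) shows that this aromatic carbon accepts it without a reading beyond the scatter. No available evidence explains this result.

As far as these compounds go, it remains open whether an amine or a carboxylic acid on the same aromatic carbon would also leave the number within the scatter. Also open, from the compounds shown here alone, is whether methoxy in place of hydrogen would give the same result on the other phenyl groups of the core.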